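Nitro added to the 4-methoxyphenyl of compound 2

The source may hold more compounds than are shown below. What is called first, only, known or untested is meant among the compounds shown, and "the series" means these compounds.

Two values are available so far. In a functional assay on MCF7 cells (Homo sapiens) for inhibition, read by CCK-8 assay, with a stated time of 48 h (on this read-out higher numbers stand for weaker inhibition and lower numbers for stronger inhibition), compound 1 (`COc1cc(-c2ccnc3cc(-c4c[nH]c5ccccc45)nn23)cc(OC)c1OC`) gives 85 nM and compound 2 (`COc1ccc(-c2cc3nccc(-c4cc(OC)c(OC)c(OC)c4)n3n2)cc1`) gives 125 nM as its reading, the two lying within the scatter of each other.

Compound 3 (`COc1ccc(-c2cc3nccc(-c4cc(OC)c(OC)c(OC)c4)n3n2)cc1[N+](=O)[O-]`) differs from compound 2 in one place: nitro in place of hydrogen on an aromatic carbon, ortho to a methoxy group and meta to a large group (nitro in place of hydrogen on an aromatic carbon).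

Going by the values given here, the only measured step (a 1.5-fold higher number from compound 1 to compound 2 (0.17 log units; within the scatter)) swaps 1H-indol-3-yl for 4-methoxyphenyl and lies within the scatter. Among the compounds with values here, it concerns the group that compound 3 alters, but no measured compound carries a nitro, so the data give no direct size for this change. The small size of that one step argues against assuming a large effect, while the added group leaves some room for a loss.

The expected outcome is a 1.6-fold higher number from compound 2 to compound 3 (0.20 log units; within the scatter) in this assay and therefore no clear step beyond the scatter, with only a slight lean toward weaker inhibition. For compound 3 the estimate is 200 nM with an expected range of 60 nM to 700 nM on this thin evidence.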

Compound 3, half-maximal inhibitory concentration: > 10000 nM
Compound 3: no number, only a limit; the forecaster's own chance of this, stated with the estimate: 3%; at least 50-fold (1.69 log units) between middle value and limit.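

In this assay, going by these compounds alone, the carbon ortho to a methoxy group on the 4-methoxyphenyl of compound 2 proves sensitive to substitution: nitro in place of hydrogen gives an at least 80-fold higher number from compound 2 to compound 3 (1.90 log units; beyond the scatter), the only step so far that lies beyond the scatter. The earlier step, a 1.5-fold higher number from compound 1 to compound 2 (0.17 log units; within the scatter), exchanged the whole aryl group at this site and gave no sign of such sensitivity, whereas here 3 heavy atoms added to that same group separate two otherwise identical compounds. The reading for compound 3 is a limit and not a number, so the full size of this step stays undefined: the limit of > 10000 nM in this assay, at which 1 of the 3 values shown sits.

Whether the loss belongs to nitro itself or would follow from any group at this place stays open, since the compounds shown carry only hydrogen or nitro there. An amine or a methyl group ortho to the methoxy group would help separate these two readings, and nitro on the 1H-indol-3-yl of compound 1 would test whether the same change carries over to the other aryl group.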